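The source may report more compounds than this note shows. Statements on the series, on what has been measured and on what is new or still open speak of the compounds shown alone.

Measured compounds in a functional assay, with a stated time of 30 min, tested at 200 uM; a higher number here means a stronger effect of the compound at the concentration tested, a lower number a weaker effect:
compound 1, `CCOC(=O)C(CS)NC(=O)c1cc(C(C)(C)C)c(O)c(C(C)(C)C)c1`: 85%
compound 2, `CCOC(=O)C(CS)NC(=O)/C=C/c1ccccc1`: 86%
compound 3, `O=C(/C=C/c1ccccc1)NCCS`: 86%

The three measured compounds sit within the usual scatter of one another in this assay, so none can be ranked. Compound 2 and compound 3 differ by hydrogen in place of ethoxycarbonyl on a saturated chain carbon bound to an amide-type nitrogen and a saturated chain carbon, and this step came out as no change at the digits printed from compound 2 to compound 3 (within the scatter). Compound 4, `CC(C)(C)c1cc(C(=O)NCCS)cc(C(C)(C)C)c1O`, is not yet measured; it differs from compound 1 by hydrogen in place of ethoxycarbonyl on a saturated chain carbon bound to an amide-type nitrogen and a saturated chain carbon, the same change at the same place. How the core of compound 1 differs from the core of compound 2 is not broken down here. Because no change at the digits printed from compound 2 to compound 3 (within the scatter), the account expects the step to be no change at the digits printed from compound 1 to compound 4 (within the scatter). Compound 4 is therefore estimated at 85%, between 74% and 93%.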

Compound 4, a percentage reported as activity, at one concentration (the size of the read-out at that concentration, not a potency): 85%
Compound 4: middle estimate and measured number agree at the digits printed; measured number inside the range.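

In this assay, hydrogen in place of ethoxycarbonyl gives no change at the digits printed from compound 1 to compound 4 (within the scatter), and the change reads the same on both cores: the same change on two cores in this assay, no change at the digits printed (within the scatter) from compound 2 to compound 3 and no change at the digits printed (within the scatter) from compound 1 to compound 4, 0 percentage points apart, within the scatter of two such steps Within this series, then, the ethoxycarbonyl group can be exchanged for hydrogen on either core without any visible difference in this read-out. This rests on two cores only and on a read-out at one concentration, so it does not show that the change would carry to a further core, nor that potency is the same.

The compounds shown leave open what a carboxylic acid or a primary amide would give in place of ethoxycarbonyl. They also leave open what a longer chain would give in place of 2-sulfanylethyl, or a hydroxyl group in place of the sulfanyl group.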